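The source may hold more compounds than are shown below. What is called first, only, known or untested is meant among the compounds shown, and "the series" means these compounds.

Measured compounds:
- compound 1, `CCN1CCN(c2cc(C)c3cc(NC(=O)c4cccc(Cl)c4)ccc3n2)CC1`: 3820 nM
- compound 2, `Cc1cc(N(C)C)nc2ccc(NC(=O)c3ccc(Cl)c(Cl)c3)cc12`: 33300 nM
- compound 3, `Cc1cc(N2CCN(C)CC2)nc2ccc(NC(=O)c3ccc(Cl)c(Cl)c3)cc12`: 3000 nM

In a functional assay on MCF7 cells (Homo sapiens) for antiproliferative activity, read by MTT assay, with a stated time of 72 h (a lower number here means a stronger inhibitor, a higher number a weaker inhibitor), compound 1 gives 3820 nM, the second highest of the three numbers. Its nearest neighbour is compound 3 at 3000 nM, a gap within the scatter, so the two cannot be told apart. Compound 2, at 33300 nM, lies far above both. Among the compounds with values here, the only step between two measured compounds that differ in one place is an 11-fold lower number from compound 2 to compound 3 (1.05 log units; beyond the scatter), and it concerns the amine on the core, not the chlorinated ring of the amide.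

Compound 4, `CCN1CCN(c2cc(C)c3cc(NC(=O)c4ccccc4Cl)ccc3n2)CC1`, has not yet been measured. It differs from compound 1 by 2-chlorophenyl in place of 3-chlorophenyl on a carbonyl carbon: the same atoms, with the chlorine moved on the phenyl ring of the amide. Within the data shown here, none of the measured steps touches this part of the molecule, so there is no direct guide. With the amine on the core unchanged from compound 1, the step expected in this assay is small, a 1.3-fold higher number from compound 1 to compound 4 (0.12 log units; within the scatter), and not beyond the scatter in either direction. Compound 4 is therefore estimated at 5000 nM, with a range from 1800 nM to 15000 nM.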

Compound 4, half-maximal inhibitory concentration: > 50000 nM
Compound 4 was reported as a limit; the forecaster's own chance of this, stated with the estimate: 5%; at least 10-fold (1.00 log units) between middle value and limit.
By their numbers in this assay, from the lowest: compounds 3 and 1 (each within the scatter of the next); then compound 2. At a limit, above all of these: compound 4.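

Moving the chlorine alone, with the same atoms and the amine on the core unchanged, gives an at least 13-fold higher number from compound 1 to compound 4 (1.11 log units; beyond the scatter) in this assay, so the phenyl ring of the amide is not a part of the molecule where the chlorine can sit freely. Within the data shown here, the earlier compounds could not show this, as their one measured step, an 11-fold lower number from compound 2 to compound 3 (1.05 log units; beyond the scatter), concerns the amine on the core; the new step shows that a change on the other side of the molecule can also be large, even though no atom is added or removed. The reading for compound 4 is a limit of the assay and not a number, so the size of this step has a lower bound only: the limit of > 50000 nM in this assay, at which 1 of the 4 values shown sits.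

The result rests on a single pair, 3-chlorophenyl against 2-chlorophenyl, and says nothing yet about plain phenyl, with no chlorine at all. It also leaves open whether a fluorine or a methoxy group in place of the chlorine of compound 4 would behave in the same way, and whether the same move would have the same effect with the 4-methylpiperazin-1-yl group of compound 3 on the core.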